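Growth inhibition notes: from compound 3 to compound 4

The source may report more compounds than this note shows. Statements on the series, on what has been measured and on what is new or still open speak of the compounds shown alone.

- compound 1 `CNC(=O)/C=C/c1ccncc1-c1ccc2ccccc2c1`: > 10000 nM (a limit)
- compound 2 `O=C(CCc1ccncc1-c1ccc2ccccc2c1)N1CCOCC1`: > 10000 nM (a limit)
- compound 3 `COC(=O)/C=C/c1ccncc1-c1ccc2ccccc2c1`: 6730 nM

All three were read in a functional assay on KB cells (Homo sapiens) for inhibition, read by sulforhodamine B assay, with a stated time of 72 h; a higher number here means a weaker inhibitor of growth, a lower number a stronger inhibitor of growth. For the measured compounds named here, compound 3, at 6730 nM, is the only one with an actual number. The rest of the picture is the limit of > 10000 nM in this assay, at which 2 of the 3 values shown sit.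

Next to be read is compound 4 `O=C(O)CCc1ccncc1-c1ccc2ccccc2c1`. The change is 2-carboxyethyl in place of 2-(methoxycarbonyl)ethenyl on an aromatic carbon.

Going by the values given here, the one measured step at this carbonyl is an at least 1.4-fold lower number from compound 1 to compound 3 (0.17 log units; that floor lies within the scatter), so it offers little guidance on size. Like compound 4, compound 2 also lacks the chain double bond. Compound 2 gives > 10000 nM, which is a limit.

On that basis a move toward weaker growth inhibition is expected in this assay, with an estimated 2.2-fold higher number from compound 3 to compound 4 (0.35 log units; beyond the scatter). For compound 4 the expected value is 15000 nM. The estimated range for compound 4 runs from 7000 nM to 40000 nM, and a reading at the limit is likely.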

Compound 4, concentration for 50% growth inhibition: > 10000 nM
Compound 4 ended at the assay's limit; the forecaster's own chance of this, stated with the estimate: 80%; the middle value does not contradict the limit.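

In this assay compound 4 reads > 10000 nM, which is a limit. Placing 2-carboxyethyl in place of 2-(methoxycarbonyl)ethenyl, on the aromatic carbon opposite the ring nitrogen, gives an at least 1.4-fold higher number from compound 3 to compound 4 (0.17 log units; that floor lies within the scatter); this is only a floor, so the change shows no gain in growth inhibition and its full size stays unknown. For the compounds shown here, the steps from compound 1 and from compound 2 to compound 4 cannot be read, and compound 3 keeps the only actual number: the limit of > 10000 nM in this assay, at which 3 of the 4 values shown sit.

On these data alone, this single step alters both the chain double bond and the chain end, so their separate contributions remain open. Also open, as far as these compounds go, is how a 2-(methoxycarbonyl)ethyl group, a longer chain or a terminal amine would read at this position.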